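Benzyloxy addition on two amide-bearing triarylethylene cores

The source may report more compounds than this note shows. Statements on the series, on what has been measured and on what is new or still open speak of the compounds shown alone.

Measured compounds:
Compound 1 `CC/C(=C(/c1ccc(NC(=O)C(C)C)cc1)c1ccc(OC)cc1)c1ccccc1` — in a functional assay on MCF7 cells (Homo sapiens) for inhibition, read by trypan blue exclusion, with a stated time of 72 h (on this read-out lower numbers stand for stronger inhibition of growth and higher numbers for weaker inhibition of growth), compound 1 gives > 30000 nM, a limit of the assay rather than a number.
Compound 2 `CC/C(=C(/c1ccc(NC(=O)C(C)C)cc1)c1ccc(OC)cc1)c1ccc(OCc2ccccc2)cc1` — in this assay compound 2 gives 29000 nM.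
Compound 3 `CC/C(=C(/c1ccccc1)c1ccc(NC(=O)C(C)C)cc1)c1ccccc1` — in this assay compound 3 gives > 30000 nM, again a limit of the assay and not a number.

Going by the values given here, the one measured step is an at least 1.0-fold lower number from compound 1 to compound 2 (0.01 log units; that floor lies within the scatter); the change is benzyloxy in place of hydrogen on an aromatic carbon. The same change now goes from compound 3 to compound 4 `CC/C(=C(/c1ccccc1)c1ccc(NC(=O)C(C)C)cc1)c1ccc(OCc2ccccc2)cc1`: benzyloxy in place of hydrogen on an aromatic carbon. Between the cores of compound 1 and compound 3 the difference is not broken down here. Both cores, without benzyloxy, sit at the same limit, as noted in the limit of > 30000 nM in this assay, at which 2 of the 3 values shown sit.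

For compound 4 a step of a number no higher from compound 3 to compound 4 (the limit leaves the size open) in this assay is expected, resting on compound 3 with > 30000 nM and on the step of an at least 1.0-fold lower number from compound 1 to compound 2 (0.01 log units; that floor lies within the scatter), which stays within the scatter. Compound 4 is therefore estimated at 30000 nM, within 15000 nM to 60000 nM, with a real chance that only a limit is reported.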

Compound 4, concentration for 50% growth inhibition: > 30000 nM
Compound 4: no number, only a limit; the forecaster's own chance of this, stated with the estimate: 60%; the middle value sits exactly at the limit.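

Compound 4 gives > 30000 nM in this assay, a limit of the assay and not a number. Compound 3 also stands at a limit, so no step can be read from compound 3 to compound 4: the limit of > 30000 nM in this assay, at which 3 of the 4 values shown sit.

The compounds shown leave open whether benzyloxy in place of hydrogen on an aromatic carbon changes growth inhibition on the core of compound 3.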